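A few compounds are considered here, and "the series" means these few. Any claim that something is new, unique, unknown or untested is made for them only; others in the source may bear on it.

Working notes on the series. Compound 1 `O=C1NCCC12CCN(c1c(Cl)cncc1-c1ccoc1)CC2` carries a furan-3-yl on an aromatic carbon of the shared core. Among the compounds with values here, in a functional assay on MV4-11 cells (Homo sapiens) for inhibition, read by resazurin assay, with a stated time of 72 h (on this read-out lower numbers stand for stronger inhibition of growth and higher numbers for weaker inhibition of growth), compound 1 gives 750 nM, the highest of the three numbers measured so far. Compound 2 `O=C1NCCC12CCN(c1c(Cl)cncc1-c1ccsc1)CC2` gives 190 nM and compound 3 `Cc1csc(-c2cncc(Cl)c2N2CCC3(CCNC3=O)CC2)c1` gives 650 nM. Among these, a 3.9-fold lower number from compound 1 to compound 2 (0.60 log units; beyond the scatter), whereas a 1.2-fold lower number from compound 1 to compound 3 (0.06 log units; within the scatter) and a 3.4-fold higher number from compound 2 to compound 3 (0.53 log units; beyond the scatter).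

Compound 4 `O=Cc1sccc1-c1cncc(Cl)c1N1CCC2(CCNC2=O)CC1` is not yet measured. It differs from compound 1 in one place: 2-formylthiophen-3-yl in place of furan-3-yl on an aromatic carbon. The step that bears most directly on this change is the exchange of furan-3-yl for thiophen-3-yl, a 3.9-fold lower number from compound 1 to compound 2 (0.60 log units; beyond the scatter), a modest move to a lower number. The further exchange to 4-methylthiophen-2-yl, a 3.4-fold higher number from compound 2 to compound 3 (0.53 log units; beyond the scatter), shows that changing the thiophene itself moves the number by a comparable amount, there in the other direction. Within the data shown here, no measured pair shows what a formyl group on the thiophene does, so that part of the change has no precedent here.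

Compound 4 is therefore expected to land between compound 1 and compound 2, a modest step of a 2.3-fold lower number from compound 1 to compound 4 (0.37 log units; beyond the scatter) in this assay. The estimate for compound 4 is 320 nM, with a range from 110 nM to 950 nM.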

Compound 4, concentration for 50% growth inhibition: 28700 nM
Compound 4: middle estimate off by 90-fold (1.95 log units), on the low side, and the stated range ends below it.
By their numbers in this assay, from the lowest: compound 2; then compounds 3 and 1 (each within the scatter of the next); then compound 4.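

In this assay the one-place addition of formyl in place of hydrogen on the thiophene gives a 150-fold higher number from compound 2 to compound 4 (2.18 log units; beyond the scatter) and is the largest step in the series, whereas the earlier exchanges were modest or within the scatter. The same large shift appears against the other two groups, with a 38-fold higher number from compound 1 to compound 4 (1.58 log units; beyond the scatter) and a 44-fold higher number from compound 3 to compound 4 (1.64 log units; beyond the scatter) as the remaining comparisons, so this position on the shared core, ortho to a large group, accommodates furan-3-yl, thiophen-3-yl and 4-methylthiophen-2-yl with far smaller changes than 2-formylthiophen-3-yl. No measurement shown here accounts for the loss.

The compounds shown leave open whether the loss belongs to the formyl group itself or to any substituent on that thiophene carbon, such as a methyl, a hydroxymethyl or a carboxylic acid. They also leave open what a formyl group does on another carbon of the thiophene.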